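The compounds below may be only part of what the source reports. "The series", "measured", "known", "first", "only" and "open" are said of these compounds alone.

Measured so far:

Compound 1, `CCC(C)(C)Cc1c[nH]c(CCc2ccc(-n3cccn3)cc2)n1`: 33 nM
Compound 2, `CCC(C)(C)Cc1c[nH]c(CCc2ccc(-c3csnn3)cc2)n1`: 45 nM

Both numbers come from an in vitro assay on CHO cells for displacement of a labelled ligand from Bombesin receptor subtype-3 (Homo sapiens), read by scintillation counting, with a stated time of 2 h; on this read-out lower numbers stand for stronger inhibition and higher numbers for weaker inhibition. Among the compounds with values here, on those two numbers compound 2 stands highest, with compound 1 as its only neighbour; the step of a 1.4-fold higher number from compound 1 to compound 2 (0.13 log units; within the scatter) stays within the scatter, so the two compounds cannot be ranked against each other.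

The next compound, compound 3, `CCC(C)(C)Cc1c[nH]c(CCc2ccc(-n3cncn3)cc2)n1`, keeps the shared core and changes only the five-membered aromatic ring attached to the six-membered ring of carbon only, para to a large group: 1H-1,2,4-triazol-1-yl in place of 1,2,3-thiadiazol-4-yl on an aromatic carbon.

Within the data shown here, one measured step bears on this change. Going from compound 1 to compound 2 also swapped one five-membered aromatic ring for another at the same place, and that step, a 1.4-fold higher number from compound 1 to compound 2 (0.13 log units; within the scatter), did not move the number beyond the scatter. Compound 3 is therefore expected to show no step beyond the scatter, a 1.2-fold lower number from compound 2 to compound 3 (0.07 log units; within the scatter). Compound 3 is estimated at 38 nM in this assay, with a range from 15 nM to 110 nM.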

Compound 3, half-maximal inhibitory concentration: 340 nM
Estimate against measurement, compound 3: 8.9-fold (0.95 log units) below, and the stated range ends below it.
By their numbers in this assay, from the lowest: compounds 1 and 2 (each within the scatter of the next); then compound 3.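

In this assay, this place, on the six-membered aromatic ring of carbon only and para to a large group, proves sensitive to which five-membered aromatic ring it carries, since 1H-1,2,4-triazol-1-yl gives steps beyond the scatter against both earlier rings (a 7.6-fold higher number from compound 2 to compound 3 (0.88 log units; beyond the scatter); a 10-fold higher number from compound 1 to compound 3 (1.01 log units; beyond the scatter)). The earlier swap between 1H-pyrazol-1-yl and 1,2,3-thiadiazol-4-yl had shown no such sensitivity, and the new result also shows that matching counts do not settle the outcome: 1,2,3-thiadiazol-4-yl and 1H-1,2,4-triazol-1-yl each have 5 heavy atoms, 3 hetero atoms, 0 hydrogen-bond donors and 3 hydrogen-bond acceptors, and differ in that a sulfur is replaced by a nitrogen and the ring is attached differently. No measurement here explains why the number rises with this ring.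

Only three rings are shown, so it remains open whether a 1H-imidazol-1-yl or a pyridyl group at this place would fall with compounds 1 and 2 or with compound 3. On these data alone, it is also open whether a plain phenyl group, with no ring nitrogen at all, would keep the lower numbers.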